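Swapping the benzodioxin for a dimethoxyphenyl in compound 1

The source may report more compounds than this note shows. Statements on the series, on what has been measured and on what is new or still open speak of the compounds shown alone.

Compound 1 `CN(Cc1ccc2c(c1)OCCO2)c1cc(=O)c2cc(C(F)(F)F)cc([N+](=O)[O-])c2s1` carries a methylated nitrogen on the shared core, linked through a saturated chain carbon to a 2,3-dihydro-1,4-benzodioxin-6-yl group. In an ADME assay on Vero cells (Chlorocebus sabaeus) for cytotoxicity, read by MTT assay, with a stated time of 48 h (a higher number here means a weaker inhibitor, a lower number a stronger inhibitor), compound 1 gives > 64 ug/mL, which is a limit of the assay rather than a number. Compound 3 `O=c1cc(NCc2ccc3c(c2)OCCO3)sc2c([N+](=O)[O-])cc(C(F)(F)F)cc12` differs from compound 1 by a hydrogen in place of methyl on a nitrogen on an aromatic ring. In this assay compound 3 gives > 64 ug/mL, again only a limit. The step that the two limits leave unreadable from compound 1 to compound 3 is therefore unreadable in size. Compound 2 `O=c1nc(NCc2cccc(F)c2)oc2c([N+](=O)[O-])cc(C(F)(F)F)cc12`, which has a different core, also reaches only a limit in this assay, giving > 64 ug/mL. All three values sit at the limit of > 64 ug/mL in this assay, at which 3 of the 3 values shown sit.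

Compound 4 `COc1ccc(CN(C)c2cc(=O)c3cc(C(F)(F)F)cc([N+](=O)[O-])c3s2)cc1OC` differs from compound 1 by 3,4-dimethoxyphenyl in place of 2,3-dihydro-1,4-benzodioxin-6-yl on a saturated chain carbon bound to a nitrogen on an aromatic ring. Going by the values given here, no measured step bears directly on this change, and the single step between measured compounds has no readable size. With every measured compound sitting at the limit, no step beyond the scatter is expected from this change. The estimated step that the limit leaves unreadable from compound 1 to compound 4 is thus none beyond the scatter. Compound 4 is expected at 100 ug/mL, within 50 ug/mL to 300 ug/mL, and is most likely to be reported again only as a limit.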

Compound 4, half-maximal inhibitory concentration: > 64 ug/mL
Compound 4 ended at the assay's limit; the forecaster's own chance of this, stated with the estimate: 85%; the middle value does not contradict the limit.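

Compound 1 and compound 4 both reach only a limit in this assay, so no step can be read between them, and 3,4-dimethoxyphenyl in place of 2,3-dihydro-1,4-benzodioxin-6-yl has no readable size: the limit of > 64 ug/mL in this assay, at which 4 of the 4 values shown sit.

The compounds shown leave open where the actual value of any of them lies, and whether any change would bring a compound inside the measurable range of this assay.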